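This account rests on a few compounds, and the source may have more. Where it says the series, first, only, none or still open, it means among the compounds named here.

Measured compounds:
compound 1 `CC[C@H](C)[C@H](N)C(=O)NS(=O)(=O)OC[C@H]1O[C@@H](n2cnc3c(N)ncnc32)[C@H](O)[C@@H]1O` — 5600 nM
compound 2 `CC(C)[C@H](N)C(=O)NS(=O)(=O)OC[C@H]1O[C@@H](n2cnc3c(N)ncnc32)[C@H](O)[C@@H]1O` — 5600 nM

Compound 2 stands level with compound 1 at the digits shown. In a functional assay on PBMC cells (Homo sapiens) for inhibition (on this read-out lower numbers stand for stronger inhibition and higher numbers for weaker inhibition), compound 2 gives 5600 nM, and compound 1 gives 5600 nM, so the two cannot be told apart within the usual scatter of this measurement.

Compound 3 `CCC[C@H](N)C(=O)NS(=O)(=O)OC[C@H]1O[C@@H](n2cnc3c(N)ncnc32)[C@H](O)[C@@H]1O` has not yet been measured. It differs from compound 2 as follows: propyl in place of isopropyl on a saturated chain carbon bound to an amine nitrogen and a carbonyl carbon. Isopropyl leaves and propyl enters; the two compounds have the same atoms, joined differently, with no change in hydrogen-bond donors, acceptors or charge.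

Among the measured compounds shown here, only one measured step bears on this change, no change at the digits printed from compound 1 to compound 2 (within the scatter). Removing a methyl from a saturated chain carbon in that step produced no change beyond the scatter. The change to compound 3 is of a similar kind, a rearrangement of the same short side chain at the same part of the shared core. On that single precedent the step of no change at the digits printed from compound 2 to compound 3 (within the scatter) is expected to lie within the scatter. Compound 3 is therefore estimated at 5600 nM, with a range from 2500 nM to 12500 nM.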

Compound 3, half-maximal inhibitory concentration: 4700 nM
Compound 3: the middle estimate sits 1.2-fold (0.08 log units) above what was measured; the measured number falls inside the stated range.
By their numbers in this assay, from the lowest: compounds 3, 1 and 2 (each within the scatter of the next).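

At the saturated chain carbon bound to an amine nitrogen and a carbonyl carbon, the earlier pair tested only the loss of a methyl, whereas this result tests a rearrangement of the same atoms. In this assay, replacing the branched isopropyl with the unbranched propyl gives a 1.2-fold lower number from compound 2 to compound 3 (0.08 log units; within the scatter), and the comparison with the larger branched chain of compound 1 gives a 1.2-fold lower number from compound 1 to compound 3 (0.08 log units; within the scatter), so neither branching nor this difference in chain size separates the three compounds in this read-out. No supporting measurement is available that could explain this flat result.

All three compounds carry a short saturated hydrocarbon chain at this place, so the flat result says nothing about how a longer chain such as hexyl, a ring-bearing group such as benzyl, or a side chain ending in an amine or a carboxylic acid would behave. From the compounds shown here alone, it is also open whether the same insensitivity would hold for any change made elsewhere on the shared core, since all three compounds differ only in this side chain.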